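This account rests on a few compounds, and the source may have more. Where it says the series, first, only, none or still open, it means among the compounds named here.

Three compounds have been run through a functional assay on A549 cells (Homo sapiens) for antiproliferative activity, read by sulforhodamine B assay, with a stated time of 72 h (on this read-out higher numbers stand for weaker inhibition of growth and lower numbers for stronger inhibition of growth), and a fourth waits for the same test. Compound 1 `Cc1cc(=O)oc2cc(SCc3cccc(C(F)(F)F)c3)ccc12` carries a trifluoromethyl on its outer ring. In this assay compound 1 gives > 28500 nM, which is a limit of the assay rather than a number. Compound 2 `Cc1cc(=O)oc2cc(SCc3cccc(C#N)c3)ccc12` differs from compound 1 in one place, (cyano in place of trifluoromethyl on an aromatic carbon). In this assay compound 2 gives > 32500 nM, again a limit. The step that the two limits leave unreadable from compound 1 to compound 2 cannot be sized because the limit of > 28500 nM in this assay, at which 1 of the 3 values shown sits, and the limit of > 32500 nM in this assay, at which 1 of the 3 values shown sits, are both limits, so the change from trifluoromethyl to cyano left no readable mark here.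

Compound 3 `CCc1cc(=O)c2ccc(OCc3cccc(C(F)(F)F)c3)c(C)c2o1` is built on a different core; how that core differs from the core of compound 1 is not broken down here. In this assay compound 3 gives > 27600 nM, which is also a limit (the limit of > 27600 nM in this assay, at which 1 of the 3 values shown sits).

Compound 4 `CCc1cc(=O)c2ccc(OCc3cccc(C#N)c3)c(C)c2o1` arises from compound 3 by the same change, (cyano in place of trifluoromethyl on an aromatic carbon), at the same place on the outer ring. Compound 4 is expected to show weak inhibition of growth, with an estimated value of about 40000 nM in this assay and a likely range from 20000 nM to 100000 nM. The expected step that the limit leaves unreadable from compound 3 to compound 4 is an estimate of little movement, resting on compound 1 and compound 2, for which the step that the two limits leave unreadable from compound 1 to compound 2 stayed unreadable.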

Compound 4, concentration for 50% growth inhibition: > 31300 nM
Compound 4: a limit, no number; the forecaster's own chance of this, stated with the estimate: 80%; the middle value does not contradict the limit.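

In this assay compound 4 gives > 31300 nM, which is a limit and not a number. Compound 3 also stands at a limit, so no size can be read for the change from trifluoromethyl to cyano between compound 3 and compound 4. The compounds shown leave open whether this change alters growth inhibition on either core, and which structures would give a readable value in this assay.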